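Adding a second methoxy on the aryl ring of compound 3

A few compounds are considered here, and "the series" means these few. Any claim that something is new, unique, unknown or untested is made for them only; others in the source may bear on it.

Compound 3, `COc1ccc(-c2cc(C(=O)Nc3nc4ccc(F)cc4s3)nc3cc(-c4ccccc4)nn23)cc1`, was measured in a functional assay on MCF7 cells (Homo sapiens) for cytotoxicity, read by MTT assay, with a stated time of 48 h (on this read-out higher numbers stand for weaker inhibition and lower numbers for stronger inhibition), and gave 35500 nM. Among the three measured compounds it carries the highest number. Compound 2, `O=C(Nc1nc2ccc(F)cc2s1)c1cc(-c2ccc(F)cc2)n2nc(-c3ccccc3)cc2n1`, gives 22900 nM in this assay, and the step of a 1.6-fold higher number from compound 2 to compound 3 (0.19 log units; within the scatter) lies within the scatter. Within the data shown here, compound 1, `COc1ccc(-c2cc(C(=O)Nc3nc4ccc(Cl)cc4s3)nc3cc(-c4ccccc4)nn23)cc1OC`, gives 6910 nM in this assay; no single step connects it to compound 3, but the gap between the two values lies beyond the scatter.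

Compound 4, `COc1ccc(-c2cc(C(=O)Nc3nc4ccc(F)cc4s3)nc3cc(-c4ccccc4)nn23)cc1OC`, differs from compound 3 by methoxy in place of hydrogen on an aromatic carbon. Compound 4 thus shares the 3,4-dimethoxyphenyl group with compound 1 while keeping the fluoro of compound 3. Among the measured compounds shown here, the only measured step near this change, the one from compound 2 to compound 3, was small, so a methoxy exchange on this ring has so far moved the number little. Compound 1, though, with the same dimethoxy pattern, stands well lower than compound 3. Compound 4 is therefore expected to move toward a lower number, by a step estimated at a 2.4-fold lower number from compound 3 to compound 4 (0.37 log units; beyond the scatter). The estimate for compound 4 in this assay is 15000 nM, within a range from 5000 nM to 45000 nM.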

Compound 4, half-maximal inhibitory concentration: 22400 nM
For compound 4 the middle estimate is 1.5-fold (0.17 log units) below the measured one; low and high end bracket the measured number.
By their numbers in this assay, from the lowest: compound 1; then compounds 4, 2 and 3 (each within the scatter of the next).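

In this assay the added methoxy, ortho to a methoxy group, gives a 1.6-fold lower number from compound 3 to compound 4 (0.20 log units; within the scatter) and so does not set the 3,4-dimethoxyphenyl group apart from the 4-methoxyphenyl group in the fluoro compounds. The exchange of the whole aryl group gives a 1.0-fold lower number from compound 2 to compound 4 (0.01 log units; within the scatter) and likewise does not set the 3,4-dimethoxyphenyl group apart from the 4-fluorophenyl group. Among these compounds, the one step here that leaves the scatter lies at the other place, where fluoro in place of chloro gives a 3.2-fold higher number from compound 1 to compound 4 (0.51 log units; beyond the scatter) with the 3,4-dimethoxyphenyl group held constant, so the lower number of compound 1 goes with its chloro and not with the dimethoxy pattern alone. Nothing at hand bears on why these steps have the size they do.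

Chloro appears in only one of these compounds, so it remains open whether the same exchange would shift the number with the 4-methoxyphenyl or 4-fluorophenyl group in place. Also open, on these data alone, is whether an amine, a carboxylic acid or a longer chain such as ethoxy on that aromatic ring would move the number further than methoxy does.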